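The source may report more compounds than this note shows. Statements on the series, on what has been measured and on what is new or still open speak of the compounds shown alone.

Measured in a functional assay on A549 cells (Homo sapiens) for antiproliferative activity, read by MTT assay, with a stated time of 48 h; a lower number here means a stronger inhibitor, a higher number a weaker inhibitor:
- compound 1 `Cn1cc(-c2cnc3ccc(N)nc3c2)cn1`: > 50000 nM
- compound 2 `Cn1cc(-c2cnc3ccnc(N)c3c2)cn1`: 33400 nM

Compound 1 has no exact number. Its result is a limit of the assay, (the limit of > 50000 nM in this assay, at which 1 of the 2 values shown sits). Compound 2, a close relative, does give a number, 33400 nM, which is still a large value in this assay and so marks a weak inhibitor.

The next compound is compound 3 `CC(=O)Nc1ccc2ncc(-c3cnn(C)c3)cc2n1`, which keeps the core of compound 1 and changes one group: acetyl in place of hydrogen on a nitrogen on an aromatic ring. In short, amino becomes acetamido. For the measured compounds named here, no pair of measured compounds shows what this kind of change does, and the limit for compound 1 gives no exact starting point. The expectation therefore rests on compound 2, whose 33400 nM suggests that compounds of this kind stay weak. No clear gain or loss is expected in this assay, and the estimated change is an at least 1.2-fold lower number from compound 1 to compound 3 (0.09 log units; that floor lies within the scatter). Compound 3 may well return only a limit too. The estimate for compound 3 is 40000 nM, with an expected range from 12000 nM to 90000 nM.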

Compound 3, half-maximal inhibitory concentration: > 50000 nM
Compound 3 was reported as a limit; the forecaster's own chance of this, stated with the estimate: 55%; at least 1.2-fold (0.09 log units) between middle value and limit.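

For the compounds shown here, compound 3, like compound 1, gives only a limit and not an exact number, so no step from compound 1 to compound 3 can be read: the limit of > 50000 nM in this assay, at which 2 of the 3 values shown sit. From the compounds shown here alone, whether acetyl in place of hydrogen on that nitrogen changes the strength of inhibition in this assay, in either direction, stays open.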